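Series notes: a smaller group at the varied aromatic carbon

A few compounds are considered here, and "the series" means these few. Any claim that something is new, unique, unknown or untested is made for them only; others in the source may bear on it.

Three measured compounds share one core and differ only in the group on a single aromatic carbon. Compound 1 `COC(=O)c1cc(-c2cnc(C(=O)CCc3ccc(-c4ccccc4)cc3)o2)ccn1` gives 1.5 nM in an assay for inhibition of Fatty-acid amide hydrolase 1 (Rattus norvegicus); on this read-out lower numbers stand for stronger inhibition and higher numbers for weaker inhibition. Compound 2 `N#Cc1cccc(-c2cnc(C(=O)CCc3ccc(-c4ccccc4)cc3)o2)n1` gives 2.9 nM. Compound 3 `CN(C)C(=O)c1cnc(C(=O)CCc2ccc(-c3ccccc3)cc2)o1` gives 3 nM. Compound 3 carries the highest of the three numbers, but its nearest neighbour is compound 2 with a 1.0-fold higher number from compound 2 to compound 3 (0.01 log units; within the scatter), and the furthest is compound 1 with a 2.0-fold higher number from compound 1 to compound 3 (0.30 log units; within the scatter); both lie within the scatter, so no order among the three can be read.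

Compound 4 `CSc1cnc(C(=O)CCc2ccc(-c3ccccc3)cc2)o1` differs from compound 3 by methylsulfanyl in place of dimethylcarbamoyl on an aromatic carbon. The measured steps that bear on this all exchange the group on the same aromatic carbon: a 1.9-fold higher number from compound 1 to compound 2 (0.29 log units; within the scatter), a 2.0-fold higher number from compound 1 to compound 3 (0.30 log units; within the scatter) and a 1.0-fold higher number from compound 2 to compound 3 (0.01 log units; within the scatter). None of them moved the number beyond the scatter, and none of them involved methylsulfanyl, so the change to compound 4 is not directly covered. On the evidence of those three exchanges the step is expected to be small, at most slightly toward a higher number: a 1.7-fold higher number from compound 3 to compound 4 (0.22 log units; within the scatter). The estimate for compound 4 in this assay is 5 nM, with a range from 1.5 nM to 15 nM.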

Compound 4, inhibition constant: 3 nM
For compound 4 the middle estimate is 1.7-fold (0.22 log units) above the measured one, within the range that was stated.
By their numbers in this assay, from the lowest: compounds 1, 2, 3 and 4 (each within the scatter of the next).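

In this assay, methylsulfanyl with 2 heavy atoms in place of dimethylcarbamoyl with 5 heavy atoms, on the aromatic carbon next to the ring oxygen, gives no change at the digits printed from compound 3 to compound 4 (within the scatter) and so adds a much smaller group to the set at this position. Set against the two ring-bearing groups, the same methylsulfanyl gives a 1.0-fold higher number from compound 2 to compound 4 (0.01 log units; within the scatter) where 6-cyanopyridin-2-yl leaves and a 2.0-fold higher number from compound 1 to compound 4 (0.30 log units; within the scatter) where 2-(methoxycarbonyl)pyridin-4-yl leaves. The earlier exchanges covered only groups joined through carbon, so the new finding is that a group joined through sulfur, with no ring and no carbonyl, also stays within the scatter of the other three compounds at this position.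

Still open, from the compounds shown here alone, is whether an amine, a carboxylic acid, a longer chain such as butylsulfanyl or a plain hydrogen at this carbon would stay within that scatter, and whether any group here can move the number beyond it. Nothing available explains why these four groups give numbers so close together.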